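Chlorophenyl for methoxyphenyl: expected effect on receptor binding

This account rests on a few compounds, and the source may have more. Where it says the series, first, only, none or still open, it means among the compounds named here.

Compound 1 `COc1ccccc1N1CCN(C(=O)CCc2c(-c3ccccc3)[nH]c3ccc(C)cc23)CC1` gives 6.1 nM in an assay on CHO cells for displacement of a labelled ligand from Substance-P receptor (Homo sapiens); on this read-out higher numbers stand for weaker inhibition and lower numbers for stronger inhibition. Compound 2 `COc1cccc(-c2[nH]c3ccc(C)cc3c2CCC(=O)N2CCN(c3ccccc3OC)CC2)c1` has methoxy in place of hydrogen on an aromatic carbon, and in this assay compound 2 gives 8 nM; the step of a 1.3-fold higher number from compound 1 to compound 2 (0.12 log units; within the scatter) stays within the scatter. Compound 2 thus holds the higher of the two numbers shown, with compound 1 as its only neighbour and no ordering between them that the scatter would support.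

Compound 3 `COc1ccccc1N1CCN(C(=O)CCc2c(-c3ccc(Cl)cc3)[nH]c3ccc(C)cc23)CC1` differs from compound 2 by 4-chlorophenyl in place of 3-methoxyphenyl on an aromatic carbon, on an aromatic carbon of the five-membered aromatic ring with one nitrogen, next to the ring nitrogen. Going by the values given here, only a 1.3-fold higher number from compound 1 to compound 2 (0.12 log units; within the scatter) bears on this aryl group, and it was within the scatter; a chlorine here has no measured precedent. No step beyond the scatter is therefore expected, the estimated step being no change at the digits printed from compound 2 to compound 3 (within the scatter). Compound 3 is estimated at 8 nM, with a range from 3 nM to 25 nM.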

Compound 3, half-maximal inhibitory concentration: 0.6 nM
Beside the measured number, compound 3's estimate is 13-fold (1.12 log units) above it, outside the stated range (below it).
By their numbers in this assay, from the lowest: compound 3; then compounds 1 and 2 (each within the scatter of the next).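

Going by these compounds alone, the aryl group on this aromatic carbon of the five-membered ring does affect the result in this assay: 4-chlorophenyl in place of 3-methoxyphenyl gives a 13-fold lower number from compound 2 to compound 3 (1.12 log units; beyond the scatter), the first step beyond the scatter. Chloro in place of hydrogen on an aromatic carbon gives a 10-fold lower number from compound 1 to compound 3 (1.01 log units; beyond the scatter), whereas methoxy in place of hydrogen stayed within the scatter, so at this position the two substituents do not behave alike. Nothing available explains the difference.

The compounds shown do not separate the identity of the substituent from its place on the phenyl ring, since chloro appears only in 4-chlorophenyl and methoxy only in 3-methoxyphenyl. A 3-chlorophenyl and a 4-methoxyphenyl group would separate the two, and 4-bromophenyl would test whether the step is specific to chlorine.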